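This account rests on a few compounds, and the source may have more. Where it says the series, first, only, none or still open, it means among the compounds named here.

Measured in a physicochemical assay for metabolic stability, read by HPLC, tested at 2 mM; on this read-out lower numbers stand for a shorter-lived compound and higher numbers for a longer-lived compound:
- compound 1 `C[n+]1cccc(OP(=O)([O-])OC[C@H]2O[C@@H](n3cc(F)c(=O)[nH]c3=O)C[C@@H]2OC(=O)c2ccccc2)c1`: 14.8 h
- compound 2 `O=C(O[C@H]1C[C@H](n2cc(F)c(=O)[nH]c2=O)O[C@@H]1COP(=O)([O-])Oc1ccc[n+](Cc2ccccc2)c1)c1ccccc1`: 10.8 h
- compound 3 `CCOC(=O)C[n+]1cccc(OP(=O)([O-])OC[C@H]2O[C@@H](n3cc(F)c(=O)[nH]c3=O)C[C@@H]2OC(=O)c2ccccc2)c1`: 1.1 h

Compound 3 has the lowest number of these three. The next compound, compound 4 `C[N+]1(C)CCC(OP(=O)([O-])OC[C@H]2O[C@@H](n3cc(F)c(=O)[nH]c3=O)C[C@@H]2OC(=O)c2ccccc2)CC1`, has not yet been measured. It differs from compound 3 in one place: a group of 8 heavy atoms (7 carbon, 1 nitrogen; one six-membered non-aromatic ring with 1 hetero atom) in place of a group of 12 heavy atoms (9 carbon, 1 nitrogen, 2 oxygen; one six-membered aromatic ring with 1 hetero atom), on an oxygen.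

The measured steps bear on this change only in part. All of them alter a saturated chain carbon bound to an aromatic nitrogen. Phenyl in place of hydrogen gives a 1.4-fold lower number from compound 1 to compound 2 (0.14 log units; within the scatter). Ethoxycarbonyl in place of hydrogen gives a 13-fold lower number from compound 1 to compound 3 (1.13 log units; beyond the scatter), which is a large step, and ethoxycarbonyl in place of phenyl gives a 9.8-fold lower number from compound 2 to compound 3 (0.99 log units; beyond the scatter). Among these three compounds, then, the low number occurs only with ethoxycarbonyl, and the group entering compound 4 has none.

Going by the values given here, no measured step replaces the aromatic ring with a non-aromatic one, so that part of the change is untested. The two compounds without ethoxycarbonyl offer the nearest guide, compound 1 at 14.8 h and compound 2 at 10.8 h. A clear rise in this assay is therefore expected, and the expected step is a 36-fold higher number from compound 3 to compound 4 (1.56 log units; beyond the scatter). For compound 4 the estimated half-life is 40 h, with an expected range from 10 h to 200 h.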

Compound 4, half-life: > 120 h
Compound 4: no number, only a limit (the forecaster's own chance of this, stated with the estimate: 30%); middle value at least 3.0-fold (0.47 log units) from the limit.
By their numbers in this assay, from the lowest: compound 3; then compounds 2 and 1 (each within the scatter of the next). At a limit, above all of these: compound 4.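

In this assay compound 4 gives > 120 h, which is a limit of the assay and not a number. The earlier steps shown here all altered a saturated chain carbon bound to an aromatic nitrogen, whereas this change replaces the whole group on the oxygen, and it brings an at least 100-fold higher number from compound 3 to compound 4 (2.03 log units; beyond the scatter), even though the leaving and entering groups both carry a net charge of +1. Losing ethoxycarbonyl is not the whole story, since compound 1 also lacks that group and the change from its aromatic ring to the non-aromatic ring of compound 4 still gives an at least 8.1-fold higher number from compound 1 to compound 4 (0.90 log units; beyond the scatter), so a six-membered non-aromatic ring on this oxygen can outlast both the ethoxycarbonyl compound and the compounds without it.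

Going by these compounds alone, the limit leaves the true size of both steps unknown, and the single non-aromatic example cannot separate the loss of aromaticity from the extra carbon in the entering group. From the compounds shown here alone, whether ethoxycarbonyl on a chain at the ring nitrogen would lower the number on the non-aromatic ring as well, or how a morpholine ring would behave at this oxygen, remains open.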